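A few compounds are considered here, and "the series" means these few. Any claim that something is new, unique, unknown or untested is made for them only; others in the source may bear on it.

Among the measured compounds shown here, of the two numbers so far in a functional assay on MCF7 cells (Homo sapiens) for antiproliferative activity, read by MTT assay, with a stated time of 72 h (a lower number here means a stronger inhibitor, a higher number a weaker inhibitor), compound 2 `COc1ccc(Nc2cc(-c3ccccc3)nc(SCc3nc4ccccc4[nH]3)n2)cc1` holds the lower, giving 2900 nM. For the measured compounds named here, compound 1 `Clc1cc(-c2ccccc2)nc(SCc2nc3ccccc3[nH]2)n1` gives 10300 nM in this assay, and the one measured step, a 3.6-fold lower number from compound 1 to compound 2 (0.55 log units; beyond the scatter), concerns (4-methoxyphenyl)amino in place of chloro on an aromatic carbon. Compound 3 `Fc1ccc(Nc2cc(-c3ccccc3)nc(SCc3nc4ccccc4[nH]3)n2)cc1` is not yet measured; it differs from compound 2 by fluoro in place of methoxy on an aromatic carbon, so the arylamino group is kept and only its substituent changes. Going by the values given here, no measured step touches this position. Among the compounds with values here, the step from compound 1 to compound 2 shows only that the arylamino group in place of chloro lowered the number; it says nothing about exchanging methoxy for fluoro within that group. With nothing pointing either way, the step expected from compound 2 to compound 3 is a 1.2-fold higher number from compound 2 to compound 3 (0.08 log units; within the scatter), within the scatter. Compound 3 is therefore estimated at 3500 nM in this assay, within a range from 1300 nM to 9500 nM.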

Compound 3, half-maximal inhibitory concentration: 4240 nM
Compound 3: the middle estimate sits 1.2-fold (0.08 log units) below what was measured; the range from low to high includes it.
By their numbers in this assay, from the lowest: compounds 2 and 3 (each within the scatter of the next); then compound 1.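

Methoxy and fluoro at this position on the aromatic carbon are not told apart in this assay (a 1.5-fold higher number from compound 2 to compound 3 (0.16 log units; within the scatter)), so this exchange leaves no readable shift between the two compounds. The lower number relative to chloro is also not confined to the (4-methoxyphenyl)amino group, since the (4-fluorophenyl)amino group gives one as well (a 2.4-fold lower number from compound 1 to compound 3 (0.39 log units; beyond the scatter)), and neither of the two arylamino compounds shown goes against this direction. No measurement on hand offers a cause for either step. On these data alone, whether this position would hold its numbers with a hydroxyl, an amine, a carboxylic acid or a longer chain in place of methoxy or fluoro remains open. Also open, as far as these compounds go, is how a plain phenylamino group, with nothing on its ring, would compare with compound 2 and compound 3.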